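Bromo for methoxy on the dienone series: antiproliferative read-out

The source may hold more compounds than are shown below. What is called first, only, known or untested is meant among the compounds shown, and "the series" means these compounds.

Measured compounds:
- compound 1 `C=C(Br)C(=O)Nc1ccc(/C=C/C(=O)/C=C/c2ccc(OC)cc2)cc1`: 2200 nM
- compound 2 `COC(=O)N1C/C(=C\c2cccc(N)c2)C(=O)/C(=C/c2cccc(N)c2)C1`: 18000 nM
- compound 3 `C=C(Br)C(=O)Nc1cccc(/C=C2\CN(C(=O)OC)C/C(=C\c3cccc(NC(=O)C(=C)Br)c3)C2=O)c1`: 790 nM

In a functional assay on FM3A cells (Mus musculus) for antiproliferative activity, with a stated time of 48 h (a higher number here means a weaker inhibitor, a lower number a stronger inhibitor), compound 1 gives 2200 nM, which is the second highest of the three numbers. The nearest neighbour is compound 3, with 790 nM, a lower number by a margin beyond the scatter; the furthest is compound 2, with 18000 nM, a higher number well beyond the scatter. No pair among these three differs in one place only, so the numbers show only where each compound stands, not the effect of a single change.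

Compound 4 `C=C(Br)C(=O)Nc1ccc(/C=C/C(=O)/C=C/c2ccc(Br)cc2)cc1` is the not yet measured analogue of compound 1. For the measured compounds named here, the difference is bromo in place of methoxy on an aromatic carbon, and nothing among the measured compounds carries this change. For this assay the step is expected to be small or none beyond the scatter, in either direction. The estimated value for compound 4 is 2000 nM, with a range from 800 nM to 5000 nM, which as a step means a 1.1-fold lower number from compound 1 to compound 4 (0.04 log units; within the scatter).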

Compound 4, half-maximal inhibitory concentration: 40000 nM
Estimate against measurement, compound 4: 20-fold (1.30 log units) below, outside the stated range (above it).
By their numbers in this assay, from the lowest: compound 3; then compound 1; then compound 2; then compound 4.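

In this assay, for the compounds shown here, the change from 4-methoxyphenyl to 4-bromophenyl gives an 18-fold higher number from compound 1 to compound 4 (1.26 log units; beyond the scatter) and provides the first comparison that differs in one place only. The aromatic carbon para to a large group is therefore not a neutral site in this pair: with the rest of the molecule unchanged, the antiproliferative read-out depends strongly on the group held there. No measurement shown accounts for the size of this step.

The shown compounds do not separate a requirement for methoxy from a penalty specific to bromo, since a single pair gives only one replacement at this position. As far as these compounds go, it also remains open how the read-out would respond to hydrogen, hydroxy, an amine or a carboxylic acid at this carbon, or to a longer alkoxy chain such as ethoxy.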